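Paw edema inhibition: swapping a hydroxyphenyl for a pyridyl

The source may report more compounds than this note shows. Statements on the series, on what has been measured and on what is new or still open speak of the compounds shown alone.

Measured so far:
- compound 1 `O=C(N/N=C/c1cccc(O)c1)c1cccnc1Nc1cccc(C(F)(F)F)c1`: 65.4%
- compound 2 `COc1cc(/C=N/NC(=O)c2cccnc2Nc2cccc(C(F)(F)F)c2)cc(OC)c1OC`: 40.6%
- compound 3 `CN(C)c1ccc(/C=N/NC(=O)c2cccnc2Nc2cccc(C(F)(F)F)c2)cc1`: 51.4%

All three compounds share one core and were tested in a functional assay on the whole organism (strain Wistar) for inhibition, with Rattus norvegicus as the target, read by paw edema, with a stated time of 2 h, at a dose of 10 mg/kg by the intraperitoneal route; on this read-out higher numbers stand for more inhibition at the one dose given (going by the name of the read-out) and lower numbers for less inhibition. Compound 1 gives 65.4%, the highest of the three numbers. Compound 3 stands nearest, and compound 2 furthest, with 40.6%.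

Among the compounds with values here, the one single-point step measured is a number 14 percentage points lower from compound 1 to compound 3 (beyond the scatter), where a 4-(dimethylamino)phenyl replaced the 3-hydroxyphenyl on a carbon with a double bond to nitrogen. That step was modest but beyond the scatter.

Compound 4 `O=C(N/N=C/c1cccnc1)c1cccnc1Nc1cccc(C(F)(F)F)c1` has not yet been measured. It differs from compound 1 by pyridin-3-yl in place of 3-hydroxyphenyl on a carbon with a double bond to nitrogen. Within the data shown here, since only the step from compound 1 to compound 3 touches the same place, and it went down, a downward step of similar or smaller size is expected here as well: a number 13.4 percentage points lower from compound 1 to compound 4 (beyond the scatter). Compound 4 is therefore estimated to give 52%, in a range from 36% to 66%.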

Compound 4, a percentage reported as inhibition, in the whole organism at one dose (the size of the read-out at that dose, not a potency): 62.4%
The estimate for compound 4 lay 10.4 percentage points below the measured number; the range from low to high includes it.
By their numbers in this assay, from the lowest: compound 2; then compound 3; then compounds 4 and 1 (each within the scatter of the next).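

In this assay, the step of a number 3 percentage points lower from compound 1 to compound 4 (within the scatter) shows that at this place, on a carbon with a double bond to nitrogen, a ring with 0 hydrogen-bond donors can stand in for the 3-hydroxyphenyl without a change beyond the scatter. The step of a number 11 percentage points higher from compound 3 to compound 4 (beyond the scatter) adds that the earlier fall with 4-(dimethylamino)phenyl does not apply to every replacement of the 3-hydroxyphenyl, since pyridin-3-yl does not repeat it. Nothing available here gives a reason for either step.

Still open, on these data alone, is what a plain phenyl would give, with neither the hydroxyl nor the ring nitrogen, and so whether either atom matters at this place. Pyridin-4-yl would show whether the location of the ring nitrogen counts.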